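From a Methoxy to an Isopropoxy Ether: Compound 4

A few compounds are considered here, and "the series" means these few. Any claim that something is new, unique, unknown or untested is made for them only; others in the source may bear on it.

Three compounds have been measured in an ADME assay on liver for metabolic stability, with Liver microsome (Rattus norvegicus) as the target, using microsomes; on this read-out lower numbers stand for a shorter-lived compound and higher numbers for a longer-lived compound:
compound 1 `Cc1nc(-c2cc3cc(OCC(C)C)ccc3[nH]2)sc1C(=O)O` gives 1.61 h;
compound 2 `Cc1nc(-c2cc3cc(NCc4ccccc4)cc(C#N)c3[nH]2)sc1C(=O)O` gives 1.5 h;
compound 3 `COc1cc([N+](=O)[O-])c2[nH]c(-c3nc(C)c(C(=O)O)s3)cc2c1` gives 0.402 h.

Compound 3 stands lowest of the three. Its nearest neighbour is compound 2, whose number is higher by a margin beyond the scatter, and compound 1 lies higher still, also beyond the scatter.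

Compound 4 `Cc1nc(-c2cc3cc(OC(C)C)cc([N+](=O)[O-])c3[nH]2)sc1C(=O)O` has not yet been measured. It differs from compound 3 in one place: isopropyl in place of methyl on an oxygen on an aromatic ring. Cut one bond further out, methoxy becomes isopropoxy.

Among the compounds with values here, no measured pair shows this change directly, so its size is unknown. A small upward step, near the edge of the scatter, is expected in this assay, giving a 1.5-fold higher number from compound 3 to compound 4 (0.17 log units; within the scatter). For compound 4 the expected value is 0.6 h, between 0.25 h and 1.5 h.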

Compound 4, half-life: 4.13 h
Beside the measured number, compound 4's estimate is 6.9-fold (0.84 log units) below it; measured number outside the range, above it.
By their numbers in this assay, from the lowest: compound 3; then compounds 2 and 1 (each within the scatter of the next); then compound 4.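

In this assay the group on this oxygen turns out to matter greatly: isopropyl in place of methyl gives a 10-fold higher number from compound 3 to compound 4 (1.01 log units; beyond the scatter). A change this small, with no ring and no hydrogen-bond donor or acceptor entering or leaving, is enough to shift the half-life by a large step at this one place.

On these data alone, whether ethoxy or cyclobutoxy on the same oxygen would give a similar step, and whether isopropoxy would do the same on a core without the nitro group, stays open. Nothing at hand says why the half-life moves so far.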